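Swapping the nitrophenyl arm for a thiophene ring

The compounds below may be only part of what the source reports. "The series", "measured", "known", "first", "only" and "open" are said of these compounds alone.

Measured compounds:
compound 1 `COc1cc(C(=O)c2sc(-c3cccc([N+](=O)[O-])c3)cc2N)cc(OC)c1OC`, 7.5 nM
compound 2 `COc1cc(C(=O)c2sc(-c3cc(OC)c(OC)c(OC)c3)cc2N)cc(OC)c1OC`, 1200 nM

In a functional assay on MOLT-4 cells (Homo sapiens) for antiproliferative activity (a lower number here means a stronger inhibitor, a higher number a weaker inhibitor), compound 1 gives 7.5 nM, the lowest of the two numbers shown; compound 2 gives 1200 nM, a much higher number, beyond the usual scatter. Compound 3 `COc1cc(C(=O)c2sc(-c3cccs3)cc2N)cc(OC)c1OC` has not been measured. It differs from compound 1 in one place: thiophen-2-yl in place of 3-nitrophenyl on an aromatic carbon. A group of 9 heavy atoms gives way to one of 5, with one fewer hydrogen-bond acceptor. Within the data shown here, no measured pair isolates this kind of swap, so the expectation rests on compound 1 alone. The step of an 8.0-fold higher number from compound 1 to compound 3 (0.90 log units; beyond the scatter) is expected to be a loss of potency beyond the scatter. Compound 3 is estimated at 60 nM, within 10 nM to 500 nM.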

Compound 3, half-maximal inhibitory concentration: 8.9 nM
The estimate for compound 3 lay 6.7-fold (0.83 log units) above the measured number, and the stated range ends above it.
By their numbers in this assay, from the lowest: compounds 1 and 3 (each within the scatter of the next); then compound 2.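

In this assay, thiophen-2-yl replaces 3-nitrophenyl with the step of a 1.2-fold higher number from compound 1 to compound 3 (0.07 log units; within the scatter), so the nitro group and the six-membered ring are not needed for activity at this position. The position still responds to what sits there: compound 2, which carries a different aromatic ring in the same place, gives 1200 nM. Nothing measured here explains why these two groups match.

As far as these compounds go, it remains open whether this position needs an aromatic ring at all. A morpholine, a carboxylic acid or a short alkyl chain in its place would test that.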